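From 3-hydroxyphenyl to 4-hydroxyphenyl in compound 4

This account rests on a few compounds, and the source may have more. Where it says the series, first, only, none or still open, it means among the compounds named here.

Among the measured compounds shown here, in a functional assay on HeLa cells (Homo sapiens) for inhibition, read by MTT assay, with a stated time of 72 h (a higher number here means a weaker inhibitor, a lower number a stronger inhibitor), three compounds have numbers so far. Compound 1 `COc1cc(NC(C)CCCNC(=O)Nc2cccc(O)c2)c2ncccc2c1` gives 48000 nM, the highest of the three and therefore the weakest inhibitor among them. Compound 2 `COc1cc(NC(C)CCCNC(=O)NNC(=O)Nc2cccc(C(F)(F)F)c2)c2ncccc2c1` gives 4900 nM, and compound 3 `COc1cc(NC(C)CCCNC(=O)NNC(=O)Nc2cc(C(F)(F)F)cc(C(F)(F)F)c2)c2ncccc2c1` gives 17000 nM. Both of these lie below compound 1 by more than the usual scatter.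

The next compound to be tested, compound 4 `COc1cc(NC(C)CCCNC(=O)Nc2ccc(O)cc2)c2ncccc2c1`, has the same atoms as compound 1, joined differently: 4-hydroxyphenyl in place of 3-hydroxyphenyl on an amide-type nitrogen. In words, 4-hydroxyphenyl stands in place of 3-hydroxyphenyl on an amide-type nitrogen.

For the measured compounds named here, only one measured step bears on this, and only loosely: a 3.5-fold higher number from compound 2 to compound 3 (0.54 log units; beyond the scatter). That modest step comes from trifluoromethyl in place of hydrogen on an aromatic carbon, in compounds that also differ from compound 1 elsewhere. It suggests that one small change can shift the number in this assay, but no measurement shows what a change of hydroxyphenyl does. No direction can be argued from these data, so no step beyond the scatter is expected. The estimated step is a 1.2-fold lower number from compound 1 to compound 4 (0.08 log units; within the scatter). For compound 4 the expected value is 40000 nM, with an estimated range from 15000 nM to 100000 nM.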

Compound 4, half-maximal inhibitory concentration: 70000 nM
For compound 4 the middle estimate is 1.8-fold (0.24 log units) below the measured one; low and high end bracket the measured number.
By their numbers in this assay, from the lowest: compound 2; then compound 3; then compounds 1 and 4 (each within the scatter of the next).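

In this assay, putting 4-hydroxyphenyl in place of 3-hydroxyphenyl on an amide-type nitrogen gives a 1.5-fold higher number from compound 1 to compound 4 (0.16 log units; within the scatter) and so leaves the number within the usual scatter of repeated measurements. Among the compounds shown here, compounds 2 and 3 differ only by a trifluoromethyl on an aromatic carbon, so this is the first pair in which the hydroxyphenyl group itself is the only difference, and here the two hydroxyphenyl groups, which have the same atoms joined differently, cannot be told apart by this measurement. No measurement at hand explains this result or says what either hydroxyphenyl group contributes in these cells.

On these data alone, it remains open whether the hydroxyl matters at all, and whether a plain phenyl, or an amine or a carboxylic acid in place of the hydroxyl on that ring, would shift the number beyond the scatter. As far as these compounds go, it is also open how much of the gap between compounds 1 and 4 on one side and compounds 2 and 3 on the other belongs to the aromatic group and how much to the linking chain, since those compounds differ in more than one place.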